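Fluoro in Place of Chloro on an Aromatic Carbon

The compounds below may be only part of what the source reports. "The series", "measured", "known", "first", "only" and "open" are said of these compounds alone.

In a functional assay on KB cells (Homo sapiens) for inhibition, read by MTT assay, with a stated time of 24 h, tested at 0.1 ug/mL (a lower number here means less inhibition of growth, a higher number more inhibition of growth at the concentration tested), compound 1 (`O=C(CCCCC(S)CCS)Nc1ccccc1`) gives 9.49%. Compound 2 (`O=C(CCCCC(S)CCS)Nc1ccc(Cl)cc1`), which carries a chloro group, gives 9.11%. With only these two numbers available, compound 2 stands level with compound 1, because the gap between them, a number 0.4 percentage points lower from compound 1 to compound 2 (within the scatter), does not exceed the ordinary spread of repeated measurements.

The next compound, compound 3 (`O=C(CCCCC(S)CCS)Nc1ccc(F)cc1`), has not yet been measured. Its structure differs from that of compound 2 in one place: fluoro in place of chloro on an aromatic carbon. This puts fluoro in place of chloro on an aromatic carbon, para to a large group.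

Among the compounds with values here, only one measured step bears on this change, the one that put chloro in place of hydrogen on the same carbon. That step, a number 0.4 percentage points lower from compound 1 to compound 2 (within the scatter), gives no sign that a group at this place moves the number, although a single step is thin evidence. No change beyond the scatter is therefore expected, and the expected step is a number 0.4 percentage points higher from compound 2 to compound 3 (within the scatter). In this assay the estimate for compound 3 is 9.5%, with an expected range from 2% to 18%.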

Compound 3, percent growth inhibition at one concentration: 6.78%
Beside the measured number, compound 3's estimate is 2.7 percentage points above it; measured number inside the range.
By their numbers in this assay, from the lowest: compounds 3, 2 and 1 (each within the scatter of the next).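

In this assay, exchanging one halogen for the other on this aromatic carbon, para to a large group, gives a number 2.3 percentage points lower from compound 2 to compound 3 (within the scatter) and so does not separate the two halogens. Measured against the unsubstituted ring, fluoro in place of hydrogen gives a number 2.7 percentage points lower from compound 1 to compound 3 (within the scatter) and, like the chloro step, a number 0.4 percentage points lower from compound 1 to compound 2 (within the scatter) remains within the ordinary spread, so this position now has two different halogens that leave the number level with hydrogen, where before there was only one. Nothing available bears on why these three compounds read alike.

The compounds shown leave open whether a group of another kind at this place, such as an amine, a methoxy group or a carboxylic acid, would produce a step beyond the scatter. They also leave open whether a longer chain in the core of compound 1 would shift the number, and whether the three compounds would still stand level at a higher concentration than the single one used here.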